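The source may report more compounds than this note shows. Statements on the series, on what has been measured and on what is new or still open speak of the compounds shown alone.

Measured in a functional assay on ECV-304 cells (Homo sapiens) for cytotoxicity; on this read-out higher numbers stand for weaker inhibition and lower numbers for stronger inhibition:
Compound 1 `Cc1ccc(S(=O)(=O)NN2C(=S)S/C(=C\c3ccc(Cl)c(Cl)c3)C2O)cc1`: > 50000 nM (a limit)
Compound 2 `COc1ccc(S(=O)(=O)NN2C(=S)S/C(=C\c3ccc(Cl)c(Cl)c3)C2O)cc1`: > 50000 nM (a limit)

In this assay compound 2 stands at > 50000 nM, which is a limit of the assay and not a number. Neither measured compound yields a number, and the evidence comes down to the limit of > 50000 nM in this assay, at which 2 of the 2 values shown sit.

Compound 3 `O=S(=O)(NN1C(=S)S/C(=C\c2ccc(Cl)c(Cl)c2)C1O)c1ccc(Cl)cc1` has not yet been measured. It differs from compound 2 by chloro in place of methoxy on an aromatic carbon, para to a large group: chloro in place of methoxy on an aromatic carbon.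

Going by the values given here, only one measured step bears on this change, the replacement of methyl by methoxy on an aromatic carbon: a step that the two limits leave unreadable from compound 1 to compound 2. Its size cannot be read, so it offers no measure of how much a change at this carbon moves the read-out. With no readable step to go on, no direction can be given, and no shift beyond the scatter is expected. The expected change is a number no higher from compound 2 to compound 3 (the limit leaves the size open). Compound 3 is estimated at 50000 nM, with an expected range from 25000 nM to 100000 nM, and a report as a limit alone is the likeliest outcome.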

Compound 3, half-maximal inhibitory concentration: > 50000 nM
Compound 3 was reported as a limit; the forecaster's own chance of this, stated with the estimate: 80%; the middle value sits exactly at the limit.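

In this assay, going by these compounds alone, compound 3 gives > 50000 nM, which is a limit of the assay and not a number, so no step among compound 1, compound 2 and compound 3 can be read. The compounds shown leave open whether methyl, methoxy and chloro at this aromatic carbon differ at all in this read-out.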